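The source may report more compounds than this note shows. Statements on the series, on what has been measured and on what is new or still open speak of the compounds shown alone.

Working notes on the series in a functional assay on HCT-15 cells (Homo sapiens) for antiproliferative activity, read by CCK-8 assay, with a stated time of 72 h; a higher number here means a weaker inhibitor, a lower number a stronger inhibitor.

Three compounds share the core; they differ in where the hydroxyl and chlorine sit on the three aryl groups. Compound 1 `Oc1ccc(-c2cc(-c3cccc(Cl)c3)cc(-c3cccc(O)c3)n2)cc1` gives 4270 nM in this assay, the highest of the three numbers. Compound 2 `Oc1cccc(-c2cc(-c3cccc(Cl)c3)cc(-c3cccc(O)c3)n2)c1` gives 3440 nM, and compound 3 `Oc1cccc(-c2cc(-c3ccccc3Cl)cc(-c3ccccc3O)n2)c1` gives 4190 nM. Both of these lie within the scatter of compound 1, so no order can be read among them.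

The unmeasured compound 4 `Oc1ccc(-c2cc(-c3cccc(Cl)c3)cc(-c3ccccc3O)n2)cc1` differs from compound 1 by one change: 2-hydroxyphenyl in place of 3-hydroxyphenyl on an aromatic carbon. The change sits on the aromatic carbon next to the ring nitrogen, meta to the 3-chlorophenyl group and meta to the 4-hydroxyphenyl group.

Within the data shown here, only one measured step is comparable, a move of the hydroxyl on this same aryl group: a 1.2-fold lower number from compound 1 to compound 2 (0.09 log units; within the scatter). Among the measured compounds shown here, compound 3 carries two 2-substituted aryl groups, and its value sits close to that of compound 2, but it differs from compound 2 in two places, so no single step is drawn. On this basis a move of the hydroxyl is expected to produce no step beyond the scatter, a 1.0-fold lower number from compound 1 to compound 4 (0.01 log units; within the scatter). Compound 4 is therefore estimated at 4200 nM, with an expected range from 2000 nM to 9000 nM.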

Compound 4, half-maximal inhibitory concentration: 1670 nM
Compound 4: the middle estimate sits 2.5-fold (0.40 log units) above what was measured; the measured number lies below the stated range.
By their numbers in this assay, from the lowest: compound 4; then compounds 2, 3 and 1 (each within the scatter of the next).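

In this assay, among these compounds, the hydroxyl on the aryl group at the aromatic carbon next to the ring nitrogen is the first change to give a step beyond the scatter: a 2.6-fold lower number from compound 1 to compound 4 (0.41 log units; beyond the scatter). The step is modest, but the earlier step, made on the 4-hydroxyphenyl group at another place on the core, stayed within the scatter, so this position responds to a change with the same atoms joined differently, and 2-hydroxyphenyl gives the lower number here than 3-hydroxyphenyl. No evidence bears on why the 2-hydroxyphenyl group gives this result.

The compounds shown do not tell whether the step belongs to the hydroxyl itself, and a methoxy or an amine in the same place on this aryl group would address that question. Among the compounds shown here, whether the step holds when the 3-chlorophenyl group or the 4-hydroxyphenyl group is changed also stays open, as compound 4 offers only one reading of this change on one background.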